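Aryl amide variation on a dimethoxy core

This account rests on a few compounds, and the source may have more. Where it says the series, first, only, none or still open, it means among the compounds named here.

The series shares one core, and the three measured compounds differ only in the ring carried by the amide-type nitrogen. Compound 1 `COc1cc2c(cc1OC)C(CC(=O)Nc1cccc(Cl)c1)CC2` gives 38.9% in a functional assay on the whole organism (strain Wistar) for inhibition, with Rattus norvegicus as the target, read by paw edema, with a stated time of 6 h, at a dose of 100 mg/kg; a higher number here means more inhibition at the dose given (going by the name of the read-out), a lower number less inhibition. That number is the second highest of the three: compound 2 `COc1cc2c(cc1OC)C(CC(=O)Nc1ccc(Br)cc1)CC2` gives 46.3%, and the step of a number 7.4 percentage points higher from compound 1 to compound 2 (within the scatter) lies within the scatter, while compound 3 `COc1cc2c(cc1OC)C(CC(=O)Nc1ccccc1C)CC2` gives 25.9%, a step of a number 13 percentage points lower from compound 1 to compound 3 (beyond the scatter) that lies beyond it. The further step a number 20.4 percentage points lower from compound 2 to compound 3 (beyond the scatter) shows that the ring on this nitrogen can move the read-out by a modest amount.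

Compound 4 `COc1cc2c(cc1OC)C(CC(=O)Nc1cccnc1)CC2` has not been measured. It differs from compound 1 as follows: pyridin-3-yl in place of 3-chlorophenyl on an amide-type nitrogen. Going by the values given here, no measured step exchanges a carbon-only ring for one with a hetero atom at this position, so the measured steps bear on it only loosely: they show changes on this nitrogen ranging from within the scatter to modest. The step from compound 1 to compound 4 is therefore expected to be small or modest, with the downward direction judged slightly more likely, as a number 8.9 percentage points lower from compound 1 to compound 4 (within the scatter). Compound 4 is estimated to give 30%, within a range from 15% to 48%.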

Compound 4, a percentage reported as inhibition, in the whole organism at one dose (the size of the read-out at that dose, not a potency): 35.2%
For compound 4 the middle estimate is 5.2 percentage points below the measured one; measured number inside the range.
By their numbers in this assay, from the lowest: compounds 3, 4, 1 and 2 (each within the scatter of the next, the first and the last beyond it).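

In this assay, going by these compounds alone, pyridin-3-yl is the first ring with a hetero atom on the amide-type nitrogen, and exchanging 3-chlorophenyl for it gives a number 3.7 percentage points lower from compound 1 to compound 4 (within the scatter), so on these numbers this exchange cannot be told apart from no change. The other two steps place compound 4 within the series, with a number 9.3 percentage points higher from compound 3 to compound 4 (within the scatter) and a number 11.1 percentage points lower from compound 2 to compound 4 (beyond the scatter), which leaves it separated beyond the scatter only from the 4-bromophenyl compound, even though compounds 1 and 3 are themselves separated beyond the scatter. No measurement shown here bears on what lies behind these numbers, so they describe the read-out at this position without explaining it.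

From the compounds shown here alone, it remains open whether the placement of the ring nitrogen matters, as pyridin-2-yl and pyridin-4-yl would show, and whether a ring carrying an amine or a carboxylic acid would stay in the same range. Going by these compounds, a benzyl group on the amide-type nitrogen is also open, and with one dose in one assay, these percentages say nothing about potency.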